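Swapping the Sulfonamide Amine in a Urea Series

The compounds below may be only part of what the source reports. "The series", "measured", "known", "first", "only" and "open" are said of these compounds alone.

Measured so far:
compound 1 `O=C(NCc1cnccn1)Nc1ccc(S(=O)(=O)c2ccccc2)cc1` — 1300 nM
compound 2 `O=C(NCc1cccnc1)Nc1ccc(S(=O)(=O)N2C3CCC2COC3)cc1` — 10 nM

In an assay on isolated protein for inhibition of Nicotinamide phosphoribosyltransferase (Homo sapiens), read by spectrophotometry, with stated times of 15 min and 30 min (a higher number here means a weaker inhibitor, a lower number a stronger inhibitor), compound 2 gives the lower of the two numbers, and compound 1 sits far higher, beyond the scatter. Compound 3 `CC1CNCCN(S(=O)(=O)c2ccc(NC(=O)NCc3cccnc3)cc2)C1` differs from compound 2 by a group of 8 heavy atoms (6 carbon, 2 nitrogen; one seven-membered non-aromatic ring with 2 hetero atoms) in place of a group of 8 heavy atoms (6 carbon, 1 nitrogen, 1 oxygen; one five-membered non-aromatic ring with 1 hetero atom, one six-membered non-aromatic ring with 2 hetero atoms), on a sulfonyl sulfur. Going by the values given here, no measured pair shows this kind of swap, so its effect is unknown. A modest weakening is expected for compound 3, since the bicyclic amine of compound 2 is replaced by a simpler cyclic diamine, giving an expected step of a 3.0-fold higher number from compound 2 to compound 3 (0.48 log units; beyond the scatter). Compound 3 is estimated at 30 nM, within 8 nM to 150 nM.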

Compound 3, half-maximal inhibitory concentration: 100 nM
Beside the measured number, compound 3's estimate is 3.3-fold (0.52 log units) below it, and the stated range covers the measured number.
By their numbers in this assay, from the lowest: compound 2; then compound 3; then compound 1.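

The group on the sulfonyl sulfur clearly affects the result: putting the seven-membered ring with 2 hetero atoms in place of the group with five- and six-membered rings gives a 10-fold higher number from compound 2 to compound 3 (1.00 log units; beyond the scatter). Both groups have 8 heavy atoms, so a matching heavy-atom count does not keep the number unchanged at this position. Nothing available explains the size of this step.

From the compounds shown here alone, it remains open whether the ring arrangement or the hydrogen-bond donor present only in compound 3 accounts for the step. Going by these compounds, how a morpholine or a diethylamino group would behave on the sulfonyl sulfur also remains open.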